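Fluoro Added to a Difluorophenyl: Cytotoxicity Outlook

The source may report more compounds than this note shows. Statements on the series, on what has been measured and on what is new or still open speak of the compounds shown alone.

Compound 1 `CC(c1ccc(C(F)(F)F)cc1)N1CC2(CCN(c3nc(=O)c4cc(C(F)(F)F)cc([N+](=O)[O-])c4s3)CC2)C1` in an ADME assay on Vero cells (Chlorocebus sabaeus) for cytotoxicity (a lower number here means that less compound is tolerated, a higher number that more compound is tolerated), gives > 64 ug/mL, a limit of this assay. Compound 2 `CC(c1ccc(OC(F)(F)F)cc1)N1CCC2(CC1)CN(c1nc(=O)c3cc(C(F)(F)F)cc([N+](=O)[O-])c3s1)C2` in this assay gives > 64 ug/mL, also a limit. Compound 3 `CC(c1cc(F)cc(F)c1)N1CC2(CCN(c3nc(=O)c4cc(C(F)(F)F)cc([N+](=O)[O-])c4s3)CC2)C1` in this assay gives > 64 ug/mL, again a limit.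

Compound 3 therefore stands at the ceiling of what this assay reports, together with both other compounds, as the limit of > 64 ug/mL in this assay, at which 3 of the 3 values shown sit, shows. The step that the two limits leave unreadable from compound 1 to compound 3 cannot be read. Compound 4 `CC(c1cc(F)c(F)c(F)c1)N1CC2(CCN(c3nc(=O)c4cc(C(F)(F)F)cc([N+](=O)[O-])c4s3)CC2)C1` differs from compound 3 by fluoro in place of hydrogen on an aromatic carbon. Within the data shown here, no measured step gives a readable size, so no step beyond the scatter is expected in this assay, and compound 4 is expected to sit at a number no higher from compound 3 to compound 4 (the limit leaves the size open). Compound 4 is estimated at 64 ug/mL, within 32 ug/mL to 128 ug/mL.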

Compound 4, half-maximal cytotoxic concentration: > 64 ug/mL
Compound 4 ended at the assay's limit (the forecaster's own chance of this, stated with the estimate: 85%); the middle value lies on the limit itself.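

No step can be read among compound 1, compound 3 and compound 4, because all of them sit at one limit: the limit of > 64 ug/mL in this assay, at which 4 of the 4 values shown sit.

The compounds shown leave open whether the added fluoro of compound 4 changes the read-out in this assay at all.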